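The compounds below may be only part of what the source reports. "The series", "measured", "known", "first", "only" and "open" are said of these compounds alone.

Compound 1, `CC(=O)Nc1ccc(S(=O)(=O)Nc2cccc(-c3nc(-c4ccc(NC(=O)c5cccnc5)cc4Cl)no3)c2)cc1`, gives 2500 nM in a functional assay on MDA-MB-231 cells (Homo sapiens) for antiproliferative activity, read by MTT assay, with a stated time of 72 h; a lower number here means a stronger inhibitor, a higher number a weaker inhibitor.
Compound 2, `O=C(Nc1ccc(-c2noc(-c3cccc(NS(=O)(=O)c4ccc(NC(=O)N5CCOCC5)cc4)c3)n2)c(Cl)c1)c1cccnc1`, gives in this assay only a limit, > 10000 nM.
Compound 3, `O=C(Nc1ccc(Cl)cc1)Nc1cccc(-c2nc(-c3ccc(NC(=O)c4cccnc4)cc3Cl)no2)c1`, gives in this assay only a limit, > 10000 nM.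

Compound 3 is therefore not placed by a number: it sits at the limit of > 10000 nM in this assay, at which 2 of the 3 values shown sit, and its true potency may lie anywhere weaker than that edge. Compound 4, `CS(=O)(=O)Nc1ccc(NC(=O)Nc2cccc(-c3nc(-c4ccc(NC(=O)c5cccnc5)cc4Cl)no3)c2)cc1Br`, is built from compound 3 by one change, (3-bromo-4-(methanesulfonamido)phenyl in place of 4-chlorophenyl on an amide-type nitrogen). Among the measured compounds shown here, only one measured step is available in this assay, an at least 4.0-fold higher number from compound 1 to compound 2 (0.60 log units; beyond the scatter), and it alters a group on a carbonyl carbon elsewhere on the shared core, so it does not speak directly to a change on the amide-type nitrogen. For the measured compounds named here, compound 1, the only compound with a number, carries a sulfonamide on the same side of the core and gives 2500 nM, which hints that a methanesulfonamido-bearing ring in that region may be tolerated; nothing shows that it is favoured. The expected step of an at least 1.4-fold lower number from compound 3 to compound 4 (0.15 log units; that floor lies within the scatter) in this assay is small, and compound 4 is estimated to land near 7000 nM, within 1500 nM to 20000 nM, with a real chance that compound 4 again returns only a limit.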

Compound 4, half-maximal inhibitory concentration: 700 nM
Compound 4: middle estimate off by 10-fold (1.00 log units), on the high side; measured number outside the range, below it.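

Replacing 4-chlorophenyl with 3-bromo-4-(methanesulfonamido)phenyl on the amide-type nitrogen gives an at least 14-fold lower number from compound 3 to compound 4 (1.15 log units; beyond the scatter) in this assay, so what sits on this nitrogen can matter a great deal for activity against these cells. The ring itself remains a six-membered aromatic ring of carbon only; the change lies in what it carries, as the chlorine leaves while a bromine and a methanesulfonamido group enter, bringing 1 hydrogen-bond donor and 2 hydrogen-bond acceptors. Compound 3 gives only a limit, not a number, so this step is a floor and the real gap may be wider: the limit of > 10000 nM in this assay, at which 2 of the 4 values shown sit.

The bromine and the methanesulfonamido group arrive together in one change, so the compounds shown cannot say whether one of them alone accounts for the step or whether both are needed. They also leave open how the same ring would behave on this nitrogen if it carried an amine or a carboxylic acid in place of the methanesulfonamido group.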